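The source may hold more compounds than are shown below. What is called first, only, known or untested is meant among the compounds shown, and "the series" means these compounds.

Compound 1 `Cc1cccc(-n2nncc2CN2C(=O)C3(C(C#N)=C(N)Oc4c3c3nc5ccccc5nc3c3ccccc43)c3ccccc32)c1`: > 50000 nM
Compound 2 `N#CC1=C(N)Oc2c(c3nc4ccccc4nc3c3ccccc23)C12C(=O)N(Cc1cnnn1-c1ccc(Cl)c(Cl)c1)c1ccccc12`: > 50000 nM
Compound 3 `Cc1ccccc1-n1nncc1CN1C(=O)C2(C(C#N)=C(N)Oc3c(N)cc4nc5ccccc5nc4c32)c2ccccc21`: > 50000 nM

Each of these three values is a limit of an ADME assay on HUVEC cells (Homo sapiens) for antiproliferative activity, read by MTT assay, with a stated time of 48 h (on this read-out higher numbers stand for weaker inhibition and lower numbers for stronger inhibition), not a measured number. All three sit at the same limit (the limit of > 50000 nM in this assay, at which 3 of the 3 values shown sit), so none of them can be ranked against another. Going by the values given here, the one paired change, a step that the two limits leave unreadable from compound 1 to compound 2, cannot be sized since both ends are limits. Compound 3 therefore stands only as a limit, level with the other two.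

Compound 4 `N#CC1=C(N)Oc2c(N)cc3nc4ccccc4nc3c2C12C(=O)N(Cc1cnnn1-c1ccccc1Cl)c1ccccc12` differs from compound 3 by chloro in place of methyl on an aromatic carbon. Among the compounds with values here, no measured step bears on this change, and the one available step is unreadable. Within the data shown here, with every value so far at the limit, compound 4 is expected to stay there, giving an expected step that the limit leaves unreadable from compound 3 to compound 4 of nothing beyond the scatter. Compound 4 is estimated at 60000 nM, within 20000 nM to 200000 nM.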

Compound 4, half-maximal inhibitory concentration: > 50000 nM
Compound 4 gave a limit, no number (the forecaster's own chance of this, stated with the estimate: 85%); the middle value does not contradict the limit.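

Going by these compounds alone, compound 3 and compound 4 are both limits, not measured numbers, so no step between them can be read: the limit of > 50000 nM in this assay, at which 4 of the 4 values shown sit.

The compounds shown leave open whether 2-methylphenyl and 2-chlorophenyl differ at all in activity.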